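Pyrimidin-2-yl in place of oxazol-2-yl on the aryl ether

The source may hold more compounds than are shown below. What is called first, only, known or untested is meant among the compounds shown, and "the series" means these compounds.

For the measured compounds named here, compound 2 `C[C@@H](Oc1cc2oc(=O)n(CCC(=O)O)c2cc1Cl)c1ncco1` was measured in an assay for inhibition of kynurenine 3-monooxygenase (Homo sapiens), read by mass spectrometry, with a stated time of 1 h (a higher number here means a weaker inhibitor, a lower number a stronger inhibitor), and gives 3.16 nM, the highest of the two numbers so far. Going by the values given here, its nearest neighbour is compound 1 `C[C@@H](Oc1cc2oc(=O)n(CCC(=O)O)c2cc1Cl)c1cccnn1`, which in this assay gives 1.26 nM; the single change between them, pyridazin-3-yl to 1,3-oxazol-2-yl on the saturated chain carbon bound to an oxygen on the aromatic ring, moved the number a 2.5-fold higher number from compound 1 to compound 2 (0.40 log units; beyond the scatter). Compound 3 `C[C@@H](Oc1cc2oc(=O)n(CCC(=O)O)c2cc1Cl)c1ncccn1` has not yet been measured in this assay. It differs from compound 2 only at that same carbon: pyrimidin-2-yl in place of 1,3-oxazol-2-yl on a saturated chain carbon bound to an oxygen on an aromatic ring and a saturated chain carbon. Among the compounds with values here, only the step from compound 1 to compound 2 bears on this change, and it swapped a six-membered ring with two hetero atoms for a five-membered one at a modest cost. Since compound 3 restores a six-membered ring with two nitrogens, a modest gain back toward the number of compound 1 is expected, estimated as a 1.8-fold lower number from compound 2 to compound 3 (0.24 log units; within the scatter). Compound 3 is therefore expected to give about 1.8 nM in this assay, within a range of 0.8 nM to 4 nM.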

Compound 3, half-maximal inhibitory concentration: 5.01 nM
Estimate against measurement, compound 3: 2.8-fold (0.44 log units) below; measured number outside the range, above it.
By their numbers in this assay, from the lowest: compound 1; then compounds 2 and 3 (each within the scatter of the next).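

In this assay, pyrimidin-2-yl and 1,3-oxazol-2-yl on this saturated chain carbon cannot be told apart, with a 1.6-fold higher number from compound 2 to compound 3 (0.20 log units; within the scatter), so among these two compounds a six-membered aromatic ring in place of a five-membered one makes no readable difference. The new comparison with pyridazin-3-yl, a 4.0-fold higher number from compound 1 to compound 3 (0.60 log units; beyond the scatter), shows that a six-membered aromatic ring with 2 hetero atoms is not enough to match compound 1, so ring size and hetero atom count alone do not track the numbers across these three compounds. No measurement is available to explain either step.

The compounds shown leave open whether the lower number of compound 1 is particular to pyridazin-3-yl or would also be seen with other groups on this carbon, such as pyridin-2-yl, phenyl or an amine. They also leave open whether these steps would hold on a version of the shared core with a longer chain carrying the carboxylic acid.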